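The compounds below may be only part of what the source reports. "The series", "measured", "known", "first", "only" and "open" are said of these compounds alone.

Two esters of a shared core have been examined so far. Compound 1 `C=C1CC[C@@H]2[C@](C)(COC(=O)/C=C/c3ccccc3)[C@H](O)CC[C@@]2(C)[C@@H]1/C=C/C1=CCOC1=O` gives 183000 nM in an ADME assay on HepG2 2.2.15 cells (Homo sapiens) for cytotoxicity, read by MTT assay; on this read-out lower numbers stand for higher toxicity in this test and higher numbers for lower toxicity in this test. Compound 2 `C=C1CC[C@@H]2[C@](C)(COC(=O)c3ccc(OC)nc3)[C@H](O)CC[C@@]2(C)[C@@H]1/C=C/C1=CCOC1=O` carries a 6-methoxypyridin-3-yl group in place of the 2-phenylethenyl group on the carbonyl carbon, and in this assay compound 2 gives 1340000 nM. That single change produced a 7.3-fold higher number from compound 1 to compound 2 (0.86 log units; beyond the scatter). Among the two numbers available, compound 2 therefore stands highest, with compound 1 as its only and lower neighbour.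

Compound 3 `C=C1CC[C@@H]2[C@](C)(COC(C)=O)[C@H](O)CC[C@@]2(C)[C@@H]1/C=C/C1=CCOC1=O` is the next compound in the series. It differs from compound 2 in one place: methyl in place of 6-methoxypyridin-3-yl on a carbonyl carbon. Among the compounds with values here, the only step measured so far, from compound 1 to compound 2, replaced one aromatic group with another and moved the number up by a modest margin. Within the data shown here, no measured step removes the aromatic group altogether, so the present change has no direct precedent, and the direction of the step to compound 3 rests on the trend seen there.

Compound 3 is expected to show a 1.1-fold higher number from compound 2 to compound 3 (0.05 log units; within the scatter), so that compound 3 is estimated at 1500000 nM, with a range from 400000 nM to 5000000 nM.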

Compound 3, half-maximal cytotoxic concentration: 225000 nM
For compound 3 the middle estimate is 6.7-fold (0.82 log units) above the measured one; measured number outside the range, below it.
By their numbers in this assay, from the lowest: compounds 1 and 3 (each within the scatter of the next); then compound 2.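

Read in this assay, the new step gives a 6.0-fold lower number from compound 2 to compound 3 (0.77 log units; beyond the scatter), so replacing the 6-methoxypyridin-3-yl group on this carbonyl carbon with methyl does not preserve the high number of compound 2. The step of a 1.2-fold higher number from compound 1 to compound 3 (0.09 log units; within the scatter) lies within the scatter, even though compound 1 carries a 2-phenylethenyl group with a ring and compound 3 carries only methyl; the presence of a ring on the carbonyl carbon therefore does not by itself set the number, with compound 2 going against any simple ring-versus-no-ring reading. Nothing available explains why the 6-methoxypyridin-3-yl group stands apart from the other two groups.

The compounds shown leave open whether that separation depends on the ring nitrogen, on the methoxy group or on both, which a phenyl, a 6-methoxyphenyl or an unsubstituted pyridin-3-yl group on the same carbonyl carbon could help to separate. They also leave open whether methyl and 2-phenylethenyl mark a common level for other groups at this place, such as a butyl chain or an aminomethyl group.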